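Urea series on a shared core: shifting the methyl group

This account rests on a few compounds, and the source may have more. Where it says the series, first, only, none or still open, it means among the compounds named here.

Measured so far:
compound 1 `Cc1ccc(NC(=O)Nc2cccc(CNc3nccnc3Cl)c2)cc1`, in a functional assay on HepG2 cells (Homo sapiens) for antiproliferative activity, read by MTT assay, with a stated time of 48 h (a lower number here means a stronger inhibitor, a higher number a weaker inhibitor), compound 1 gives 11500 nM
compound 2 `O=C(Nc1ccc(Cl)cc1)Nc1cccc(CNc2nccnc2Cl)c1`, in this assay compound 2 gives 8350 nM
compound 3 `O=C(Nc1cccc(CNc2nccnc2Cl)c1)Nc1ccc(Cl)c(Cl)c1`, in this assay compound 3 gives 6170 nM

Compound 1 holds the highest of the three numbers in this assay, but every step from it is small: the nearest, a 1.4-fold lower number from compound 1 to compound 2 (0.14 log units; within the scatter), and the furthest, a 1.9-fold lower number from compound 1 to compound 3 (0.27 log units; within the scatter). The remaining step, a 1.4-fold lower number from compound 2 to compound 3 (0.13 log units; within the scatter), is likewise within the scatter. Going by the values given here, on these numbers no compound of the three can be called stronger or weaker than another.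

Compound 4 `Cc1cccc(NC(=O)Nc2cccc(CNc3nccnc3Cl)c2)c1` keeps the shared core of compound 1 and the same atoms; the change is 3-methylphenyl in place of 4-methylphenyl on an amide-type nitrogen. Among the compounds with values here, none of the measured steps bears directly on this change: each of them swaps the substituent on that aryl group for another, whereas here the methyl group stays and only its position on the ring is altered. What the measured steps do show is that three variations on that aryl group left this assay unmoved beyond the scatter. For compound 4 the expected outcome is therefore no change beyond the scatter, a 1.2-fold lower number from compound 1 to compound 4 (0.06 log units; within the scatter). Compound 4 is estimated at 10000 nM in this assay, with a range from 4500 nM to 23000 nM.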

Compound 4, half-maximal inhibitory concentration: 11200 nM
Estimate against measurement, compound 4: 1.1-fold (0.05 log units) below; the range from low to high includes it.
By their numbers in this assay, from the lowest: compounds 3, 2, 4 and 1 (each within the scatter of the next).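

Moving the methyl group from 4-methylphenyl to 3-methylphenyl on the amide-type nitrogen keeps the same atoms and alters only their arrangement, and in this assay this gives a 1.0-fold lower number from compound 1 to compound 4 (0.01 log units; within the scatter) and so adds a change of position to the earlier changes of substituent. Against the chlorinated aryl groups, the 3-methylphenyl group shows a 1.8-fold higher number from compound 3 to compound 4 (0.26 log units; within the scatter) and a 1.3-fold higher number from compound 2 to compound 4 (0.13 log units; within the scatter), which leaves all four aryl variants on this nitrogen within the scatter of one another, with no compound among them standing apart. Nothing at hand speaks to the reason for this flat result.

Still open, on these data alone, is whether a group of another kind on this aryl ring, such as a carboxylic acid or an amine, or a longer chain such as butyl in place of the methyl group, would move the number beyond the scatter. The four compounds also share the rest of the core unchanged, so the effect of replacing its chloro with an amine or a methoxy group remains an open question in this assay.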